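A few compounds are considered here, and "the series" means these few. Any claim that something is new, unique, unknown or untested is made for them only; others in the source may bear on it.

Measured so far in an ADME assay on TERT-RPE1 cells (Homo sapiens) for cytotoxicity, read by MTT assay, with a stated time of 72 h; a lower number here means a stronger inhibitor, a higher number a weaker inhibitor:
Compound 1 `C=CC/N=C1\S/C(=C\c2ccc(OC)cc2)C(=O)N1C` gives > 100000 nM, a limit of this assay.
Compound 2 `C=C1CN/C(=N/c2ccccc2)S1` gives > 100000 nM, again only a limit.
Compound 3 `COc1ccc(/C=C2/CN(C)/C(=N/c3ccc([N+](=O)[O-])cc3)S2)cc1` gives > 100000 nM, also a limit.

No number is known for compound 1 in this assay; it sits at the limit shared by all three measured compounds (the limit of > 100000 nM in this assay, at which 3 of the 3 values shown sit). Compound 4 `COc1ccc(/C=C2\S/C(=N\c3ccc(OC)cc3)N(C)C2=O)cc1` differs from compound 1 in one place: 4-methoxyphenyl in place of allyl on a double-bonded nitrogen. Going by the values given here, no measured step is available for this change, so the expectation rests on the three limits alone. A step of no real size beyond the scatter is expected from compound 1 to compound 4, a step that the limit leaves unreadable from compound 1 to compound 4, in this assay. Compound 4 is therefore estimated at 150000 nM, with a range from 50000 nM to 500000 nM, and most likely the assay will again report only a limit.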

Compound 4, half-maximal inhibitory concentration: > 100000 nM
Compound 4: only a limit was reported (the forecaster's own chance of this, stated with the estimate: 85%); the middle value is on the limit's open side.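

In this assay, compound 1 and compound 4 each give only a limit, so no step can be read between them: the limit of > 100000 nM in this assay, at which 4 of the 4 values shown sit.

The compounds shown leave open whether any member of this series reaches a measurable value in this assay.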